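The source may report more compounds than this note shows. Statements on the series, on what has been measured and on what is new or still open speak of the compounds shown alone.

Within the data shown here, compound 2 `c1ccc(-c2ccoc2)c(OCC2=NCCN2)c1` gives 0.501 nM in a functional assay for activation of Alpha-1A adrenergic receptor (Homo sapiens), read by calcium flux (on this read-out lower numbers stand for an effect already at smaller amounts and higher numbers for an effect only at larger amounts of compound), the lower of the two numbers measured so far; its nearest neighbour, compound 1 `c1ccc(-c2cnccn2)c(OCC2=NCCN2)c1`, gives 2.51 nM. Among the measured compounds shown here, the only measured step, a 5.0-fold lower number from compound 1 to compound 2 (0.70 log units; beyond the scatter), separates these two. Compound 3 `c1ccc(-c2cc[nH]n2)c(OCC2=NCCN2)c1` differs from compound 2 in one place: 1H-pyrazol-3-yl in place of furan-3-yl on an aromatic carbon. For the measured compounds named here, only the step from compound 1 to compound 2 bears on this change, and it was of modest size; that step exchanged pyrazin-2-yl for furan-3-yl, a change of ring size, whereas here the five-membered ring is kept and 1H-pyrazol-3-yl enters. Because a 5.0-fold lower number from compound 1 to compound 2 (0.70 log units; beyond the scatter) shows that the number moves when the ring at this position is exchanged, a modest step towards a higher number is expected, a 3.0-fold higher number from compound 2 to compound 3 (0.48 log units; beyond the scatter). Compound 3 is therefore estimated at 1.5 nM, with a range from 0.4 nM to 6 nM.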

Compound 3, half-maximal effective concentration: 5.01 nM
Compound 3: middle estimate off by 3.3-fold (0.52 log units), on the low side; low and high end bracket the measured number.
By their numbers in this assay, from the lowest: compound 2; then compounds 1 and 3 (each within the scatter of the next).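

Keeping the five-membered aromatic ring at this place does not keep the number in this assay: with 1H-pyrazol-3-yl in place of furan-3-yl there is a 10-fold higher number from compound 2 to compound 3 (1.00 log units; beyond the scatter), so ring size alone does not set the value. The six-membered pyrazin-2-yl and the five-membered 1H-pyrazol-3-yl cannot be told apart, with a 2.0-fold higher number from compound 1 to compound 3 (0.30 log units; within the scatter), and among these three groups only the furan-3-yl of compound 2 stands clearly apart from the other two. Nothing available gives a reason for the step from furan-3-yl to 1H-pyrazol-3-yl.

The exchange alters the ring's hetero atoms and adds a hydrogen-bond donor in a single move, so the compounds shown do not separate these two changes. Still open, going by these compounds, is how a thiophene ring, or a pyrazole carrying a methyl group on its ring nitrogen, would compare at this place.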